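Replacing the pyrazole arm with a substituted phenyl

The source may hold more compounds than are shown below. What is called first, only, known or untested is meant among the compounds shown, and "the series" means these compounds.

Compound 1 `COc1ncc(-c2ccc3ncnc(Nc4cnn(CC(=O)O)c4)c3c2)cc1NS(=O)(=O)c1ccc(F)cc1F`: 1540 nM
Compound 2 `COC(=O)Cn1cc(Nc2ncnc3ccc(-c4cnc(OC)c(NS(=O)(=O)c5ccc(F)cc5F)c4)cc23)cn1`: 1260 nM

In a functional assay on HCT-116 cells (Homo sapiens) for antiproliferative activity, read by sulforhodamine B assay, with a stated time of 72 h (a higher number here means a weaker inhibitor, a lower number a stronger inhibitor), compound 1 gives 1540 nM, while compound 2 gives 1260 nM. Compound 2 shows the lower of the two numbers, but the step of a 1.2-fold lower number from compound 1 to compound 2 (0.09 log units; within the scatter) is within the scatter, so the two stand together. Compound 3 `COc1cc(Nc2ncnc3ccc(-c4cnc(OC)c(NS(=O)(=O)c5ccc(F)cc5F)c4)cc23)ccc1OCCO` differs from compound 2 in that (4-(2-hydroxyethoxy)-3-methoxyphenyl in place of 1-((methoxycarbonyl)methyl)-1H-pyrazol-4-yl on a nitrogen on an aromatic ring). Neither measured step touches this nitrogen, so no shown step bears on it, and compound 3 is expected to fall near compound 2 with a wide range, a 1.2-fold higher number from compound 2 to compound 3 (0.08 log units; within the scatter). The estimate for compound 3 is 1500 nM, between 400 nM and 6000 nM.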

Compound 3, half-maximal inhibitory concentration: 5720 nM
Compound 3: the middle estimate sits 3.8-fold (0.58 log units) below what was measured; measured number inside the range.
By their numbers in this assay, from the lowest: compounds 2 and 1 (each within the scatter of the next); then compound 3.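

Going by these compounds alone, on the nitrogen on an aromatic ring, putting 4-(2-hydroxyethoxy)-3-methoxyphenyl in place of the pyrazole arm gives the first change beyond the scatter in this assay, with both (a 4.5-fold higher number from compound 2 to compound 3 (0.66 log units; beyond the scatter)) and (a 3.7-fold higher number from compound 1 to compound 3 (0.57 log units; beyond the scatter)) modest and pointing the same way. Within the data shown here, the methyl step on the pyrazole arm had left compound 1 and compound 2 together, so only this exchange of the whole arm shows that the group on this nitrogen can weaken the compounds. Nothing measured here explains the loss. From the compounds shown here alone, it remains open whether the loss follows from the phenyl ring itself or from its methoxy and 2-hydroxyethoxy groups. Also open, going by these compounds, is how a phenyl carrying an amine or a carboxylic acid in place of the 2-hydroxyethoxy chain would compare.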